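A few compounds are considered here, and "the series" means these few. Any claim that something is new, unique, unknown or untested is made for them only; others in the source may bear on it.

In a functional assay on SF-539 cells (Homo sapiens) for antiproliferative activity, read by sulforhodamine B assay, with a stated time of 48 h (a lower number here means a stronger inhibitor of growth, a higher number a weaker inhibitor of growth), compound 1 `Nc1nn(C(=O)Nc2ccc(Cc3ccccc3)cc2)c2ccccc12` gives 495 nM. Compound 2 `Nc1nn(C(=O)Nc2ccc(Cc3ccccc3)cc2)c2ccc(Cl)cc12` differs from it in a single place, and in this assay compound 2 gives 1510 nM. Going by the values given here, of the two numbers measured so far, compound 2 holds the higher one, and the step of a 3.1-fold higher number from compound 1 to compound 2 (0.48 log units; beyond the scatter) lies beyond the scatter.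

Compound 3 `Nc1ccc2c(c1)c(N)nn2C(=O)Nc1ccc(Cc2ccccc2)cc1` has not yet been measured. It differs from compound 2 in one place: amino in place of chloro on an aromatic carbon. Among the compounds with values here, the only measured step that bears on this carbon is a 3.1-fold higher number from compound 1 to compound 2 (0.48 log units; beyond the scatter), which shows that a change at this site can move the number in this assay by a modest amount. Within the data shown here, the group entering in compound 3 has no counterpart among the measured compounds, so the direction is not settled by the data. A modest step is the likeliest outcome, and the estimate leans toward a somewhat lower number, given that the chloro of compound 2, whose introduction gave a 3.1-fold higher number from compound 1 to compound 2 (0.48 log units; beyond the scatter), is removed.

Compound 3 is therefore expected to give about 800 nM in this assay, within a range of 250 nM to 2500 nM. This estimate means an expected step of a 1.9-fold lower number from compound 2 to compound 3 (0.28 log units; within the scatter).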

Compound 3, concentration for 50% growth inhibition: 8700 nM
Compound 3: the middle estimate sits 11-fold (1.04 log units) below what was measured, and the stated range ends below it.
By their numbers in this assay, from the lowest: compound 1; then compound 2; then compound 3.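

In this assay, this carbon proves more sensitive to substitution than the chloro compound alone could show: amino in place of hydrogen gives an 18-fold higher number from compound 1 to compound 3 (1.24 log units; beyond the scatter) and is a large step, well past the modest 3.1-fold higher number from compound 1 to compound 2 (0.48 log units; beyond the scatter) seen with chloro. Exchanging chloro for amino gives a 5.8-fold higher number from compound 2 to compound 3 (0.76 log units; beyond the scatter) and does not recover any of the ground lost with chloro, so both groups shown on this carbon give higher numbers than hydrogen, with no compound here going against that, and hydrogen remains the lowest of the three. Nothing in the data shown explains why amino raises the number further than chloro does.

On these data alone, with only hydrogen, chloro and amino represented on this carbon, it remains open whether every group placed here raises the number or whether a fluoro, methyl or methoxy group would stay close to compound 1. Also open, as far as these compounds go, is whether an acetamido or dimethylamino group would follow amino, and whether the same changes on another carbon of this ring would move the number as far.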